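The source may hold more compounds than are shown below. What is called first, only, known or untested is meant among the compounds shown, and "the series" means these compounds.

Measured compounds:
- compound 1 `NC(=S)N/N=C1/C(=O)N(CN2CCN(c3ccnc4cc(Cl)ccc34)CC2)c2cccc(Br)c21`: 40400 nM
- compound 2 `NC(=S)N/N=C1/C(=O)N(CN2CCN(c3ccnc4cc(Cl)ccc34)CC2)c2ccccc21`: 20600 nM

For the measured compounds named here, in a functional assay on MDA-MB-468 cells (Homo sapiens) for cytotoxicity, read by sulforhodamine B assay, with a stated time of 48 h (on this read-out higher numbers stand for weaker inhibition of growth and lower numbers for stronger inhibition of growth), compound 1 gives the higher of the two numbers, but the one measured step, a 2.0-fold lower number from compound 1 to compound 2 (0.29 log units; within the scatter), stays within the scatter, so neither compound can be called weaker or stronger. Compound 3 `NC(=S)N/N=C1/C(=O)N(CN2CCN(c3ccnc4cc(C(F)(F)F)ccc34)CC2)c2cccc(Br)c21` differs from compound 1 by trifluoromethyl in place of chloro on an aromatic carbon. Going by the values given here, no measured step touches this change: the step from compound 1 to compound 2 concerns the bromo and says nothing about the chloro. With no guide, the expectation is no step beyond the scatter. Compound 3 is therefore estimated at 40000 nM in this assay, range 13000 nM to 120000 nM, which means an expected 1.0-fold lower number from compound 1 to compound 3 (0.00 log units; within the scatter).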

Compound 3, concentration for 50% growth inhibition: 30400 nM
The estimate for compound 3 lay 1.3-fold (0.12 log units) above the measured number, and the stated range covers the measured number.
By their numbers in this assay, from the lowest: compounds 2, 3 and 1 (each within the scatter of the next).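

In this assay, for the compounds shown here, the step at this aromatic carbon is a 1.3-fold lower number from compound 1 to compound 3 (0.12 log units; within the scatter), the first reading at this position, since the earlier step concerned the bromo. Trifluoromethyl, with 4 heavy atoms, therefore reads the same as chloro, with 1, within the scatter, on the core of compound 1. No measurement available offers an explanation for this result.

Going by these compounds, whether an amine, a carboxylic acid or a longer alkyl chain at this carbon would give a step beyond the scatter remains open. So does whether trifluoromethyl in place of chloro reads the same without the bromo.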